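A Hydroxyamino Group in Place of the Terminal Amide

The compounds below may be only part of what the source reports. "The series", "measured", "known", "first", "only" and "open" are said of these compounds alone.

Compound 1, `CCCc1c[nH]c2ccc(F)cc12`: in an assay on isolated protein for inhibition of Myeloperoxidase (Homo sapiens), read by ELISA, with a stated time of 5 min (on this read-out lower numbers stand for stronger inhibition and higher numbers for weaker inhibition), compound 1 reaches only the limit > 100 nM.
Compound 2, `NC(=O)CCCCc1c[nH]c2ccc(F)cc12`: in this assay compound 2 gives 43 nM.
Compound 3, `CNC(=O)CCCc1c[nH]c2ccc(F)cc12`: in this assay compound 3 gives 95 nM.

Compound 3 stands at the highest of the two numbers shown; the nearest value lies at a step of a 2.2-fold higher number from compound 2 to compound 3 (0.34 log units; beyond the scatter). Compound 4, `ONCCCc1c[nH]c2ccc(F)cc12`, differs from it in one place: hydroxyamino in place of methylcarbamoyl on a saturated chain carbon, three bonds along the chain from an aromatic carbon.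

Among the measured compounds shown here, two measured steps touch this position. Adding methylcarbamoyl there gave an at least 1.0-fold lower number from compound 1 to compound 3 (0.02 log units; that floor lies within the scatter), which starts from the limit of > 100 nM in this assay, at which 1 of the 3 values shown sits, and so sets only a floor. Exchanging carbamoylmethyl for methylcarbamoyl gave a 2.2-fold higher number from compound 2 to compound 3 (0.34 log units; beyond the scatter). For the measured compounds named here, no measured step exchanges an amide for a hydroxyamino group, so the direction of this change has no direct precedent in these numbers.

The step expected for compound 4 is a 1.4-fold lower number from compound 3 to compound 4 (0.13 log units; within the scatter), a small one and within the scatter. Compound 4 is therefore estimated at 70 nM, between 15 nM and 300 nM.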

Compound 4, half-maximal inhibitory concentration: 21 nM
For compound 4 the middle estimate is 3.3-fold (0.52 log units) above the measured one, within the range that was stated.
By their numbers in this assay, from the lowest: compound 4; then compound 2; then compound 3. At a limit, above all of these: compound 1.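

In this assay the hydroxyamino group gives a clear gain over both amide chains: replacing methylcarbamoyl gives a 4.5-fold lower number from compound 3 to compound 4 (0.66 log units; beyond the scatter), and replacing carbamoylmethyl gives a 2.0-fold lower number from compound 2 to compound 4 (0.31 log units; beyond the scatter). This position therefore does not need a terminal amide carbonyl to reach the lowest number among these compounds, and the much shorter hydroxyamino group serves better here than either amide. Measured from the unsubstituted chain, the step is an at least 4.7-fold lower number from compound 1 to compound 4 (0.67 log units; beyond the scatter), which is only a floor, as its starting point is a limit: the limit of > 100 nM in this assay, at which 1 of the 4 values shown sits.

The compounds shown leave open whether a plain amine at this place would read like compound 4, which would separate the contribution of the nitrogen from that of the oxygen. On these data alone, how a carboxylic acid would compare here, and whether the hydroxyamino group would hold its gain on a longer chain, also remain open.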